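Swapping a pyrazole for a pyrimidine on a cyclic urea

A few compounds are considered here, and "the series" means these few. Any claim that something is new, unique, unknown or untested is made for them only; others in the source may bear on it.

Compound 1 `O=c1n(Cc2cc3cnccc3n2CCCC(F)(F)F)c2cnccc2n1C1CC1`: in an ADME assay on HeLa cells (Homo sapiens) for cytotoxicity, read by ATP content, with a stated time of 3 days (on this read-out higher numbers stand for lower toxicity in this test and lower numbers for higher toxicity in this test), compound 1 gives > 50000 nM, a limit of the test rather than a number.
Compound 2 `Cn1ccc(-n2c(=O)n(Cc3cc4cc(Cl)ccc4n3CCCC#N)c3cnccc32)n1`: in this assay compound 2 gives > 50000 nM, again a limit.

Compound 2 thus sits at the limit shared by both measured values (the limit of > 50000 nM in this assay, at which 2 of the 2 values shown sit). Compound 3 `N#CCCCn1c(Cn2c(=O)n(-c3ccncn3)c3ccncc32)cc2cc(Cl)ccc21` differs from compound 2 by pyrimidin-4-yl in place of 1-methyl-1H-pyrazol-3-yl on an aromatic nitrogen. Among the measured compounds shown here, with no measured step to lean on, no change beyond the usual scatter is expected in this assay. Compound 3 is therefore estimated at 50000 nM, within 20000 nM to 120000 nM. The expected step of a number no higher from compound 2 to compound 3 (the limit leaves the size open) is essentially flat.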

Compound 3, half-maximal cytotoxic concentration: > 50000 nM
Compound 3: no number, only a limit (the forecaster's own chance of this, stated with the estimate: 75%); the middle value sits exactly at the limit.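

No step can be read from compound 2 to compound 3, since both values are limits of the test: the limit of > 50000 nM in this assay, at which 3 of the 3 values shown sit.

The compounds shown leave open how far beyond that limit each of them lies in this assay.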